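This account rests on a few compounds, and the source may have more. Where it says the series, first, only, none or still open, it means among the compounds named here.

Measured in an ADME assay on MT4 cells (Homo sapiens) for activation, read by MTT assay (on this read-out higher numbers stand for lower toxicity in this test and lower numbers for higher toxicity in this test), where every value so far is a limit:
Compound 1 `O=c1cc(Cc2c(F)cccc2Cl)nc(SC2CCCC2)[nH]1` gives > 74000 nM as a limit
Compound 2 `CCC(C)Sc1nc(Cc2c(F)cccc2Cl)c(C)c(=O)[nH]1` gives > 73000 nM as a limit
Compound 3 `Cc1c(Cc2c(F)cccc2Cl)nc(SC2CCCC2)[nH]c1=O` gives > 71000 nM as a limit

Compound 3 stands only at the limit > 71000 nM and has no exact number. Compound 4 `CCC(c1nc(SC2CCCC2)[nH]c(=O)c1C)c1c(F)cccc1Cl` carries ethyl in place of hydrogen on a saturated chain carbon bound to two aromatic carbons. Two measured steps reach compound 3: a step that the two limits leave unreadable from compound 1 to compound 3 and a step that the two limits leave unreadable from compound 2 to compound 3. Neither has a readable size, and neither involves this change. No step beyond the scatter is therefore expected in this assay, and no direction can be assigned. In figures, the estimated change is an at least 1.1-fold lower number from compound 3 to compound 4 (0.04 log units; that floor lies within the scatter) as a rough expectation. Compound 4 is estimated at 64000 nM with an expected range from 30000 nM to 85000 nM in this test.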

Compound 4, half-maximal cytotoxic concentration: > 3000 nM
Compound 4 gave a limit, no number (the forecaster's own chance of this, stated with the estimate: 75%); the middle value is on the limit's open side.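

Among the compounds shown here, compound 3 and compound 4 both stand only at limits, so no step between them can be read. The compounds shown leave open whether ethyl in place of hydrogen on this saturated chain carbon changes the half-maximal cytotoxic concentration at all.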